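Swapping a sulfamoyl carbamate for trifluoromethyl on a boronate

This account rests on a few compounds, and the source may have more. Where it says the series, first, only, none or still open, it means among the compounds named here.

Compound 1 `CC1(C)C2CC1[C@]1(C)OB([C@H](CCCN=C(N)N)NC(=O)c3ccc(-c4ccccc4)c(N)c3)O[C@@H]1C2`: 4.7 nM
Compound 2 `COC(=O)NS(=O)(=O)c1ccccc1-c1ccc(C(=O)N[C@@H](CCCN=C(N)N)B2O[C@@H]3CC4CC(C4(C)C)[C@]3(C)O2)c(C)c1`: 0.64 nM

Of the compounds shown here, two have so far been measured in an assay on isolated protein for inhibition of serine protease 1 (Homo sapiens); on this read-out higher numbers stand for weaker inhibition and lower numbers for stronger inhibition. Compound 2 gives 0.64 nM in this assay, the lowest of the two numbers; compound 1 gives 4.7 nM, a higher number that lies beyond the scatter. The two differ in more than one place, so their values only set the range seen so far.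

Compound 3 `Cc1cc(-c2ccccc2C(F)(F)F)ccc1C(=O)N[C@@H](CCCN=C(N)N)B1O[C@@H]2CC3CC(C3(C)C)[C@]2(C)O1` departs from compound 2 by a single change: trifluoromethyl in place of (methoxycarbonyl)sulfamoyl on an aromatic carbon. Within the data shown here, no measured pair shows what this change does on its own. Compound 2 carries the only (methoxycarbonyl)sulfamoyl group among the measured compounds, and it holds the lower number, so an expected step in this assay is taken to run toward a higher number, of moderate size, a 4.7-fold higher number from compound 2 to compound 3 (0.67 log units; beyond the scatter). Compound 3 is therefore estimated at 3 nM, with a range from 0.8 nM to 12 nM.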

Compound 3, inhibition constant: 3.1 nM
Estimate against measurement, compound 3: 1.0-fold (0.01 log units) below; the measured number falls inside the stated range.
By their numbers in this assay, from the lowest: compound 2; then compounds 3 and 1 (each within the scatter of the next).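

Among these compounds, the pair gives the first reading of a single change at this place: in this assay, trifluoromethyl in place of (methoxycarbonyl)sulfamoyl on an aromatic carbon gives a 4.8-fold higher number from compound 2 to compound 3 (0.69 log units; beyond the scatter), so the group at this position does bear on the read-out. Compound 3, with 0 hydrogen-bond donors and 0 hydrogen-bond acceptors in the entering group, still gives 3.1 nM, so (methoxycarbonyl)sulfamoyl adds to the inhibition but is not required for it. Nothing measured here accounts for the size of this step.

The two compounds leave open which part of the (methoxycarbonyl)sulfamoyl group carries the difference, and a plain sulfonamide, a carboxylic acid or a nitrile on the same aromatic carbon would begin to separate those parts. From the compounds shown here alone, whether the same exchange gives a step of this size on another core also remains open.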